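Para-substituent removal on the benzamide of compound 3

A few compounds are considered here, and "the series" means these few. Any claim that something is new, unique, unknown or untested is made for them only; others in the source may bear on it.

Measured so far:
compound 1 `CC(=O)N1CCc2cc(CNC(=O)c3cccs3)ccc21`: 72%
compound 2 `CC(C)C(=O)N1CCc2cc(CNC(=O)c3ccc(F)cc3)ccc21`: 88%
compound 3 `CC(C)C(=O)N1CCc2cc(CNC(=O)c3ccc(Cl)cc3)ccc21`: 92%

The three compounds share a core and differ in the acyl group on the ring nitrogen and in the amide-linked aryl. In an assay on HEK293 cells for inhibition of Indoleamine 2,3-dioxygenase 1 (Homo sapiens), tested at 10 uM (a higher number here means more inhibition at the concentration tested (going by the name of the read-out), a lower number less inhibition), compound 3 gives 92%, the highest of the three numbers; compound 2 sits a number 4 percentage points higher from compound 2 to compound 3 (within the scatter), so the two cannot be ordered, while compound 1 gives 72%, a number that lies beyond the scatter from that of compound 3.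

Compound 4 `CC(C)C(=O)N1CCc2cc(CNC(=O)c3ccccc3)ccc21` is the next member. Relative to compound 3 the change is hydrogen in place of chloro on an aromatic carbon.

Among the compounds with values here, only one measured step bears on it: the swap of fluoro for chloro at the same position, which gave a number 4 percentage points higher from compound 2 to compound 3 (within the scatter). Two halogens of different size gave a step within the scatter, so the halogen contributes little that this assay resolves. Removing it to hydrogen is a somewhat larger change, so a small downward step, at most near the edge of the scatter, is expected: a number 8 percentage points lower from compound 3 to compound 4 (within the scatter). The estimate for compound 4 in this assay is 84%, within 68% to 94%.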

Compound 4, a percentage reported as inhibition, at one concentration (the size of the read-out at that concentration, not a potency): 100%
Compound 4: middle estimate off by 16 percentage points, on the low side; measured number above the stated range.
By their numbers in this assay, from the lowest: compound 1; then compounds 2, 3 and 4 (each within the scatter of the next, the first and the last beyond it).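

In this assay, hydrogen in place of chloro on the aromatic carbon gives a number 8 percentage points higher from compound 3 to compound 4 (within the scatter) and so does not separate the unsubstituted phenyl from the 4-chlorophenyl group. Hydrogen in place of fluoro gives a number 12 percentage points higher from compound 2 to compound 4 (beyond the scatter) and is the first step at this position to clear the scatter, though it is modest, and compound 3 cannot be ordered against either neighbour. These results show that a halogen at this position is not required for the read-out, and no measurement on hand accounts for the steps.

On these data alone, whether an amine, a methoxy group or a carboxylic acid at this position would hold the read-out remains open. The contribution of the acyl group on the ring nitrogen also stays unresolved, since compound 1 differs from the others in two places.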